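Swapping the Cyanoguanidine Tail for a Thiourea

This account rests on a few compounds, and the source may have more. Where it says the series, first, only, none or still open, it means among the compounds named here.

Compound 1, `CC/N=C(/NC#N)NCCCCn1nc(-c2ccccc2)ccc1=O`, was tested in a functional assay on the whole organism with Rattus norvegicus as the target, at a dose of 100 mg/kg (on this read-out higher numbers stand for more inhibition at the one dose given (going by the name of the read-out) and lower numbers for less inhibition), and gave 58.8%. Going by the values given here, that is the higher of the two numbers recorded so far; the only other compound, compound 2, `CC/N=C(/NC#N)NCCCCn1nc(C)ccc1=O`, gave 13.5% in this assay, and the step of a number 45.3 percentage points lower from compound 1 to compound 2 (beyond the scatter) came from a methyl in place of a phenyl on an aromatic carbon.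

Compound 3, `C/N=C(\S)NCCCCn1nc(-c2ccccc2)ccc1=O`, keeps the phenyl of compound 1 and instead changes the tail: a group of 4 heavy atoms (2 carbon, 1 nitrogen, 1 sulfur; no ring) in place of a group of 7 heavy atoms (4 carbon, 3 nitrogen; no ring), on an amine nitrogen. Among the compounds with values here, no measured step touches this part of the molecule, so the one step known, from compound 1 to compound 2, says nothing direct about it; it only shows that this series can move a long way on a single change. With nothing to anchor the direction, the expectation for compound 3 in this assay is a number near that of compound 1, with a wide range either side, which as a step means a number 13.8 percentage points lower from compound 1 to compound 3 (beyond the scatter). The estimate for compound 3 is therefore 45%, somewhere between 15% and 80%.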

Compound 3, a percentage reported as inhibition, in the whole organism at one dose (the size of the read-out at that dose, not a potency): 87.1%
For compound 3 the middle estimate is 42.1 percentage points below the measured one; the whole stated range lies below it.
By their numbers in this assay, from the lowest: compound 2; then compound 1; then compound 3.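

Compound 3 shows that the tail on the amine nitrogen matters as well as the phenyl: in this assay, replacing the group of 7 heavy atoms with the group of 4 heavy atoms gives a number 28.3 percentage points higher from compound 1 to compound 3 (beyond the scatter). The earlier step, the only one known before this, lowered the number by taking away the phenyl, whereas this change raises it with the phenyl kept, so the triple bond of the old tail is not needed for a high number in the whole animal. Nothing available explains the rise, either at the target or in how the rat handles the compound.

Going by these compounds alone, the single step swaps several features at once, so it leaves open whether the sulfur, the loss of the nitrile or the methyl at the end of the tail in place of the ethyl accounts for the change. A urea with oxygen in place of the sulfur, a tail ending in ethyl with the sulfur kept, and the new tail paired with methyl in place of phenyl on the shared core would each separate part of that question.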